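The source may report more compounds than this note shows. Statements on the series, on what has been measured and on what is new or still open speak of the compounds shown alone.

Measured so far:
Compound 1, `CSc1ccc(/C=N/n2c(Cc3ccc(S(C)(=O)=O)cc3)n[nH]c2=S)cc1`: 57.5%
Compound 2, `CS(=O)(=O)c1ccc(Cc2n[nH]c(=S)n2/N=C/c2ccccc2Cl)cc1`: 42.7%

Both were tested in a functional assay on HeLa cells (Homo sapiens) for cytotoxicity, read by MTT assay, with a stated time of 48 h, tested at 50 uM; a higher number here means a stronger effect of the compound at the concentration tested, a lower number a weaker effect. Compound 1 gives 57.5%, and compound 2 gives 42.7%, the lower of the two numbers. For the measured compounds named here, the only step between them, a number 14.8 percentage points lower from compound 1 to compound 2 (beyond the scatter), came with 2-chlorophenyl in place of 4-(methylsulfanyl)phenyl on a carbon with a double bond to nitrogen, and it stands beyond the usual scatter.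

Compound 3, `CS(=O)(=O)c1ccc(Cc2n[nH]c(=S)n2/N=C/c2ccccc2F)cc1`, has not yet been measured in this assay. It differs from compound 2 by fluoro in place of chloro on an aromatic carbon. Going by the values given here, no measured step shows this particular exchange, and the single step available concerns a different part of the structure, so it bears on the question only indirectly, by showing that a change at this position can move the number by a modest amount. Since the exchange here leaves the 2-substituted phenyl in place and swaps only one halogen for another, compound 3 is expected to sit close to compound 2, with a step of a number 2.7 percentage points lower from compound 2 to compound 3 (within the scatter) that stays within the scatter. The estimate for compound 3 is therefore 40%, in the range from 25% to 55%.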

Compound 3, a percentage reported as activity, at one concentration (the size of the read-out at that concentration, not a potency): 21.9%
Estimate against measurement, compound 3: 18.1 percentage points above; the whole stated range lies above it.
By their numbers in this assay, from the lowest: compound 3; then compound 2; then compound 1.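

In this assay, the exchange of chloro for fluoro, one heavy atom for another on an aromatic carbon ortho to a large group, with no change in hydrogen-bond donors, acceptors or net charge, gave a number 20.8 percentage points lower from compound 2 to compound 3 (beyond the scatter). The earlier pair had shown only that replacing the whole aryl group moves the number; this step shows that the identity of the halogen alone is enough to do so, even with the rest of compound 2 kept intact. Set against the 4-(methylsulfanyl)phenyl group, the 2-fluorophenyl group gives a number 35.6 percentage points lower from compound 1 to compound 3 (beyond the scatter), a large step that leaves compound 3 as the weakest of the three at the concentration tested. Nothing available gives a reason why the two halogens differ so much here.

With only chloro and fluoro shown at this place, it remains open whether bromo, methyl or methoxy would follow the same order or break it. Going by these compounds, the methylsulfonyl group is the same throughout these compounds, so what an amine or a carboxylic acid in its place would do to the read-out also remains open.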